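Cytotoxicity of a Shared Core After an Ester Swap

A few compounds are considered here, and "the series" means these few. Any claim that something is new, unique, unknown or untested is made for them only; others in the source may bear on it.

Compound 1, `Cc1ccc(C(=O)CSc2nc(O)c(C)c(Cc3cccc4ccccc34)n2)cc1`, was tested in a functional assay on MT4 cells (Homo sapiens) for cytotoxicity; a lower number here means that less compound is tolerated, a higher number that more compound is tolerated. In this assay compound 1 gives only a limit, >= 251000 nM. Compound 2, `COc1ccc(C(=O)CSc2nc(O)c(C)c(Cc3cccc4ccccc34)n2)cc1`, differs from compound 1 by methoxy in place of methyl on an aromatic carbon. In this assay compound 2 likewise gives only a limit, > 290000 nM. The step that the two limits leave unreadable from compound 1 to compound 2 cannot be read, since both ends sit at the limit of >= 251000 nM in this assay, at which 1 of the 2 values shown sits, and (the limit of > 290000 nM in this assay, at which 1 of the 2 values shown sits). Compound 3, `COC(=O)CSc1nc(O)c(C)c(Cc2cccc3ccccc23)n1`, has not yet been measured. It differs from compound 1 as follows: methoxy in place of 4-methylphenyl on a carbonyl carbon. Among the compounds with values here, no measured step covers this change, and the only values known for the shared core are limits, so no direction can be drawn from them. Compound 3 is expected to remain in the same region, with the step of an at least 1.2-fold lower number from compound 1 to compound 3 (0.09 log units; that floor lies within the scatter) expected to be small and a limit again the more likely result. Compound 3 is estimated at 200000 nM, between 50000 nM and 500000 nM.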

Compound 3, half-maximal cytotoxic concentration: >= 296000 nM
Compound 3 gave a limit, no number; the forecaster's own chance of this, stated with the estimate: 60%; at least 1.4-fold (0.17 log units) between middle value and limit.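

In this assay compound 3 gives only a limit, >= 296000 nM. Since compound 1 and compound 2 also sit at limits, no step among these three compounds can be read. The compounds shown leave open where the actual half-maximal cytotoxic concentration of any of them lies.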